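Side-chain shape on the shared core of compound 1

The compounds below may be only part of what the source reports. "The series", "measured", "known", "first", "only" and "open" are said of these compounds alone.

Compound 1 `Cc1nc(-c2ccc(C(F)(F)F)cc2)sc1CNc1ccc(CCCC(=O)O)cc1` stands in a functional assay on CHO cells for agonist activity at Free fatty acid receptor 1 (Homo sapiens) (a lower number here means that less compound is needed, a higher number that more compound is needed for the effect), only as a limit: compound 1 gives < 10000 nM, which is a limit of the assay and not a number, so its place among the measured values is open (the limit of < 10000 nM in this assay, at which 1 of the 3 values shown sits). Compound 2 `O=C(O)CSc1ccc(NCc2cccc(Oc3ccccc3)c2)cc1` gives 324 nM in this assay, and compound 3 `CC(CC(=O)O)c1ccc(NCc2cccc(Oc3ccccc3)c2)cc1` gives 126 nM. These two carry a core different from that of compound 1, but they differ from each other only in the chain on the aromatic carbon, and that step, a 2.6-fold lower number from compound 2 to compound 3 (0.41 log units; beyond the scatter), is the only measured change of this kind in the set.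

Compound 4 `Cc1nc(-c2ccc(C(F)(F)F)cc2)sc1CNc1ccc(C(C)CC(=O)O)cc1` keeps the core of compound 1 and alters only the chain: 1-(carboxymethyl)ethyl in place of 3-carboxypropyl on an aromatic carbon. The measured step starts from a sulfur-linked chain rather than from 3-carboxypropyl, so it bears on this change only in its destination, the 1-(carboxymethyl)ethyl group, which in compound 3 goes with 126 nM. The expectation is a modest gain in this assay, not a large one. Compound 4 is therefore estimated at 400 nM, with a range from 80 nM to 2000 nM. Against the limit of compound 1 this estimate corresponds to an expected step that the limit leaves unreadable from compound 1 to compound 4.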

Compound 4, half-maximal effective concentration: 58.9 nM
For compound 4 the middle estimate is 6.8-fold (0.83 log units) above the measured one; the whole stated range lies above it.
By their numbers in this assay, from the lowest: compound 4; then compound 3; then compound 2.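

Going by these compounds alone, compound 1 stands in this assay only as a limit, < 10000 nM, and no new step from compound 1 to compound 4 can be read. The compounds shown leave open how far 1-(carboxymethyl)ethyl in place of 3-carboxypropyl moves the number on the core of compound 1.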